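Amide Nitrogen Substituent Change on a Chromone Acrylamide

The compounds below may be only part of what the source reports. "The series", "measured", "known", "first", "only" and "open" are said of these compounds alone.

Among the measured compounds shown here, compound 2, with the structure `COc1ccc(CNC(=O)/C=C/c2coc3cc(OC)ccc3c2=O)cc1`, gives 22500 nM in a functional assay on A549 cells (Homo sapiens) for inhibition, read by MTT assay, with a stated time of 48 h (a lower number here means a stronger inhibitor, a higher number a weaker inhibitor), the highest of the two numbers measured so far. Its nearest neighbour is compound 1, whose structure is `COc1ccc2c(=O)c(/C=C/C(=O)Nc3cc(C)ccc3C)coc2c1` and which gives 15500 nM in this assay. For the measured compounds named here, the only step between measured compounds, a 1.5-fold higher number from compound 1 to compound 2 (0.16 log units; within the scatter), replaced an aryl group on the amide-type nitrogen with a benzyl group and stayed within the scatter.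

Compound 3, with the structure `COc1ccc2c(=O)c(/C=C/C(=O)Nc3ccccc3OC)coc2c1`, has not yet been measured. It differs from compound 2 by 2-methoxyphenyl in place of 4-methoxybenzyl on an amide-type nitrogen. Going by the values given here, since the one step that bears on this position, from an aryl to a benzyl group, moved the number by only a 1.5-fold higher number from compound 1 to compound 2 (0.16 log units; within the scatter), the reverse move back to an aryl group on the same nitrogen is expected to produce no step beyond the scatter in this assay, with at most a slight drift toward the number of compound 1. Compound 3 is therefore estimated at 16000 nM, with a likely range from 6000 nM to 45000 nM, which corresponds to an expected step of a 1.4-fold lower number from compound 2 to compound 3 (0.15 log units; within the scatter).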

Compound 3, half-maximal inhibitory concentration: > 100000 nM
Compound 3 gave a limit, no number; the forecaster's own chance of this, stated with the estimate: 10%; middle value at least 6.2-fold (0.79 log units) from the limit.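

In this assay compound 3 carries a limit of the assay and not a number: the limit of > 100000 nM in this assay, at which 1 of the 3 values shown sits. Even with only a limit, the data show that the amide-type nitrogen is less forgiving than the step of a 1.5-fold higher number from compound 1 to compound 2 (0.16 log units; within the scatter) suggested, since they give an at least 4.4-fold higher number from compound 2 to compound 3 (0.64 log units; beyond the scatter) and an at least 6.4-fold higher number from compound 1 to compound 3 (0.80 log units; beyond the scatter). Compound 1 and compound 3 both carry an aryl group on this nitrogen, so the choice of aryl or benzyl alone does not set the number; the groups on the aryl ring also count, and compound 1 goes against any rule that an aryl group on this nitrogen gives the weaker inhibitor.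

Compound 3 gives only a limit, so the full size of both new steps remains unknown, and the compounds shown do not separate the effect of the methoxy group itself from that of its place on the ring. They also leave open how the number would respond to an amine or a carboxylic acid on the aryl ring, or to a longer chain on the amide-type nitrogen.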